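Swapping the Side Group on a Shared Core

The compounds below may be only part of what the source reports. "The series", "measured", "known", "first", "only" and "open" are said of these compounds alone.

Compound 1 `O=C1N=C(C2C(=O)c3ccccc3C2=O)CC(c2cccc([N+](=O)[O-])c2)N1` and compound 2 `O=C1N=C(C2C(=O)c3ccccc3C2=O)CC(/C=C/c2ccccc2)N1` share one core and differ in a single group on a saturated ring carbon. In a functional assay on the whole organism for inhibition, with Rattus norvegicus as the target, read by paw edema, with stated times of 30 min and 3 h, at a dose of 10 mg/kg by the oral route (a lower number here means less inhibition, a higher number more inhibition at the dose given (going by the name of the read-out)), compound 1 gives 21%, and compound 2 gives 18%, the lowest of the two numbers shown, with compound 1 the nearest neighbour at a gap within the scatter. Compound 3 `O=C1N=C(C2C(=O)c3ccccc3C2=O)CC(c2ccc(Cl)cc2)N1` carries a further change at the same place: 4-chlorophenyl in place of 2-phenylethenyl on a saturated ring carbon. Within the data shown here, the one measured step that bears on it, a number 3 percentage points lower from compound 1 to compound 2 (within the scatter), was small. No step beyond the scatter is therefore expected in this assay, a number 3 percentage points higher from compound 2 to compound 3 (within the scatter). Compound 3 is expected to give about 21%, between 8% and 35%.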

Compound 3, a percentage reported as inhibition, in the whole organism at one dose (the size of the read-out at that dose, not a potency): 31%
Compound 3: the middle estimate sits 10 percentage points below what was measured; the measured number falls inside the stated range.
By their numbers in this assay, from the lowest: compounds 2, 1 and 3 (each within the scatter of the next, the first and the last beyond it).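

In this assay, among these compounds, 4-chlorophenyl in place of 2-phenylethenyl gives a number 13 percentage points higher from compound 2 to compound 3 (beyond the scatter) and so provides the first evidence that a change on this saturated ring carbon can move the number beyond the scatter. By contrast, 4-chlorophenyl in place of 3-nitrophenyl gives a number 10 percentage points higher from compound 1 to compound 3 (within the scatter) and so separates these two groups by no clear margin. No available evidence accounts for the larger step. On these data alone, what an amine, a carboxylic acid or a longer carbon chain on this carbon would give remains open.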